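This account rests on a few compounds, and the source may have more. Where it says the series, first, only, none or still open, it means among the compounds named here.

Measured so far in a functional assay for inhibition, with Sus scrofa as the target; on this read-out higher numbers stand for weaker inhibition and lower numbers for stronger inhibition:
- compound 1 `CC1(C)Oc2ccc(C#N)cc2[C@@H](Oc2ccc(=O)[nH]n2)[C@]1(C)O`: 6 nM
- compound 2 `CC1(C)Oc2ccc(C#N)cc2[C@@H](Oc2ccc(=O)[nH]n2)[C@@]1(O)Cc1ccccc1`: > 100000 nM (a limit)

Compound 2 reads > 100000 nM in this assay and this is a limit of the assay, not a number. It stands at the limit of > 100000 nM in this assay, at which 1 of the 2 values shown sits.

Compound 3 `CCOC[C@]1(O)[C@H](Oc2ccc(=O)[nH]n2)c2cc(C#N)ccc2OC1(C)C` has ethoxy in place of phenyl on a saturated chain carbon bound to a saturated ring carbon. The same difference reads benzyl to ethoxymethyl.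

For the measured compounds named here, one measured step bears on this change: an at least 16000-fold higher number from compound 1 to compound 2 (4.22 log units; beyond the scatter). The phenyl that leaves here is the group that entered in that step, so much of that large step is expected to be undone. The chain stays, however, so compound 3 is expected to remain a weaker inhibitor than compound 1, which reads 6 nM. In this assay a large move to a lower number, meaning stronger inhibition, is therefore expected. The expected step is an at least 330-fold lower number from compound 2 to compound 3 (2.52 log units; beyond the scatter). Compound 3 is estimated at 300 nM with an expected range of 20 nM to 5000 nM.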

Compound 3, half-maximal inhibitory concentration: 50000 nM
Compound 3: middle estimate off by 170-fold (2.22 log units), on the low side; the whole stated range lies below it.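

In this assay, the loss on this carbon does not need the phenyl ring: ethoxymethyl, with no ring and with a hydrogen-bond acceptor, still gives an 8300-fold higher number from compound 1 to compound 3 (3.92 log units; beyond the scatter). Exchanging phenyl for ethoxy gives an at least 2.0-fold lower number from compound 2 to compound 3 (0.30 log units; that floor lies within the scatter), a floor that does not separate the two side chains. Compound 2 stands at a limit of the assay, not at a number: the limit of > 100000 nM in this assay, at which 1 of the 3 values shown sits.

Across compounds 1, 2 and 3, both side chains longer than the one in compound 1 read far weaker, but where along the chain the loss sets in stays open. An ethyl or hydroxymethyl group on this carbon would test that, and an amine or a carboxylic acid at the chain end would show whether any longer chain can be carried here.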